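The source may hold more compounds than are shown below. What is called first, only, known or untested is meant among the compounds shown, and "the series" means these compounds.

Of the compounds shown here, three have been tested in a functional assay on MCF7 cells (Homo sapiens) for cytotoxicity, read by MTT assay, with a stated time of 72 h; on this read-out higher numbers stand for weaker inhibition and lower numbers for stronger inhibition. Compound 1 `O=C(Nc1ccc(Oc2ccnc3[nH]ccc23)c(F)c1)c1nn(-c2ccc(Br)cc2F)ccc1=O` gives 23500 nM. Compound 2 `O=C(Nc1ccc(Oc2ccnc3[nH]ccc23)c(F)c1)c1nn(-c2ccc(Cl)c(F)c2)ccc1=O` differs from it in one place, (4-chloro-3-fluorophenyl in place of 4-bromo-2-fluorophenyl on an aromatic nitrogen), and in this assay compound 2 gives 11600 nM, a step of a 2.0-fold lower number from compound 1 to compound 2 (0.31 log units; beyond the scatter). Compound 3 `Cn1ccc2c(Oc3ccc(NC(=O)c4nn(-c5ccc(Br)cc5F)ccc4=O)cc3F)ccnc21` carries a changed core, (methyl in place of hydrogen on an aromatic nitrogen), and in this assay compound 3 gives 14100 nM, which is a 1.7-fold lower number from compound 1 to compound 3 (0.22 log units; within the scatter). Compound 4 `Cn1ccc2c(Oc3ccc(NC(=O)c4nn(-c5ccc(Cl)c(F)c5)ccc4=O)cc3F)ccnc21` has not been measured. It stands to compound 3 as compound 2 stands to compound 1: the change is 4-chloro-3-fluorophenyl in place of 4-bromo-2-fluorophenyl on an aromatic nitrogen, the same change at the same place, on the core of compound 3. The step is expected to be about a 2.0-fold lower number from compound 3 to compound 4 (0.30 log units; within the scatter) because the same change gave a 2.0-fold lower number from compound 1 to compound 2 (0.31 log units; beyond the scatter). Compound 4 is therefore estimated at 7000 nM, expected to fall between 3500 nM and 14000 nM, resting on a single earlier pair.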

Compound 4, half-maximal inhibitory concentration: 16600 nM
For compound 4 the middle estimate is 2.4-fold (0.38 log units) below the measured one; the measured number lies above the stated range.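

In this assay, the swap to 4-chloro-3-fluorophenyl on the methylated core gives a 1.2-fold higher number from compound 3 to compound 4 (0.07 log units; within the scatter), and adding the methyl to the compounds carrying that phenyl group gives a 1.4-fold higher number from compound 2 to compound 4 (0.16 log units; within the scatter). The phenyl swap cannot be told apart between the two cores, which shows no real difference in how it behaves but does not prove that it carries over unchanged: the same change on two cores in this assay, a 2.0-fold lower number (0.31 log units; beyond the scatter) from compound 1 to compound 2 and a 1.2-fold higher number (0.07 log units; within the scatter) from compound 3 to compound 4, 2.4-fold (0.38 log units) apart, within the scatter of two such steps. The methyl reads the same way, with neither a difference between cores nor proof of a shared effect: the same change on two cores in this assay, a 1.7-fold lower number (0.22 log units; within the scatter) from compound 1 to compound 3 and a 1.4-fold higher number (0.16 log units; within the scatter) from compound 2 to compound 4, 2.4-fold (0.38 log units) apart, within the scatter of two such steps.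

The compounds shown leave open what a more different group would do, such as an amine or a carboxylic acid on the phenyl ring. They also leave open whether a longer chain in place of the methyl would move the number beyond the scatter.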